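Series notes: sulfonamide chain extension toward compound 4

This account rests on a few compounds, and the source may have more. Where it says the series, first, only, none or still open, it means among the compounds named here.

Compound 1 `CC1(C)C=C(n2ccccc2=O)c2cc(S(=O)(=O)N=[N+]=[N-])ccc2O1`: 88.3%
Compound 2 `CC1(C)C=C(n2ccccc2=O)c2cc(S(N)(=O)=O)ccc2O1`: 77.5%
Compound 3 `CNS(=O)(=O)c1ccc2c(c1)C(n1ccccc1=O)=CC(C)(C)O2`: 85.8%

In a functional assay on the whole organism (aorta) with Rattus norvegicus as the target (on this read-out lower numbers stand for smaller maximal responses and higher numbers for larger maximal responses), compound 3 stands second highest of the three numbers, nearest to compound 1 and furthest from compound 2, with both gaps inside the scatter. Compound 4 `CCNS(=O)(=O)c1ccc2c(c1)C(n1ccccc1=O)=CC(C)(C)O2` differs from compound 3 by methyl in place of hydrogen on a saturated chain carbon bound to a sulfonamide nitrogen. The measured step that bears on this part of the molecule is a number 8.3 percentage points higher from compound 2 to compound 3 (within the scatter), which stays within the scatter; a number 2.5 percentage points lower from compound 1 to compound 3 (within the scatter) also lies within the scatter, whereas a number 10.8 percentage points lower from compound 1 to compound 2 (beyond the scatter) lies beyond it. On this basis the step of a number 0.2 percentage points higher from compound 3 to compound 4 (within the scatter) is expected to stay within the scatter, with no clear direction. Compound 4 is estimated at 86%, with a range from 72% to 96%.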

Compound 4, largest response reached (Emax), in percent of the reference or control that the assay uses: 72.4%
Compound 4: the middle estimate sits 13.6 percentage points above what was measured; the measured number falls inside the stated range.
By their numbers in this assay, from the lowest: compounds 4, 2, 3 and 1 (each within the scatter of the next, the first and the last beyond it).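

The step from methylamino to ethylamino (a number 13.4 percentage points lower from compound 3 to compound 4 (beyond the scatter)) shows that, in this assay, one added methyl on the saturated chain carbon bound to the sulfonamide nitrogen can move the maximal response beyond the scatter. Ethyl in place of hydrogen on the sulfonamide nitrogen stays within the scatter (a number 5.1 percentage points lower from compound 2 to compound 4 (within the scatter)), whereas ethylamino in place of azido on the sulfonyl sulfur lies beyond it (a number 15.9 percentage points lower from compound 1 to compound 4 (beyond the scatter)). No evidence is available that accounts for this result.

On these data alone, whether a propyl chain or a cyclopropyl group on the sulfonamide nitrogen would extend this step remains open.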